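A few compounds are considered here, and "the series" means these few. Any claim that something is new, unique, unknown or untested is made for them only; others in the source may bear on it.

Measured in a functional assay on SEM cells (Homo sapiens) for cytotoxicity, with a stated time of 72 h; a lower number here means that less compound is needed, a higher number that more compound is needed for the effect:
- Compound 1 `C=C[C@@](C)(/C=C/c1ccc(Nc2ccc(F)cc2)cc1)CCC=C(C)C`: > 36600 nM, a limit.
- Compound 2 `C=C[C@@](C)(/C=C/c1ccc(Nc2ccc(F)c(F)c2)cc1)CCC=C(C)C`: > 36600 nM, a limit.
- Compound 3 `C=C[C@@](C)(/C=C/c1ccc(-c2ccccc2)cc1)CCC=C(C)C`: > 36600 nM, a limit.

Among the measured compounds shown here, compound 3 has no number on this read-out, only a limit, and the series so far stands at the limit of > 36600 nM in this assay, at which 3 of the 3 values shown sit.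

Compound 4 `C=C[C@@](C)(/C=C/c1ccc(-c2ccc(F)cc2)cc1)CCC=C(C)C` differs from compound 3 by fluoro in place of hydrogen on an aromatic carbon. This is fluoro in place of hydrogen on an aromatic carbon, para to a large group, so phenyl becomes 4-fluorophenyl.

The closest measured change is a step that the two limits leave unreadable from compound 1 to compound 2, which is also fluoro in place of hydrogen on an aromatic carbon. The other two steps replace an arylamino group with phenyl: a step that the two limits leave unreadable from compound 1 to compound 3 and a step that the two limits leave unreadable from compound 2 to compound 3. None of the three gives a size, so the series offers no measured effect of fluorine to carry over.

With no readable step to build on, no step beyond the scatter is expected in this assay, in either direction, and another limit is the likeliest report. The estimate amounts to a number no higher from compound 3 to compound 4 (the limit leaves the size open), an expected step and no more than that. For compound 4 the expected value is 36600 nM, with an estimated range from 18000 nM to 45000 nM.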

Compound 4, half-maximal effective concentration: > 36600 nM
Compound 4: a limit, no number (the forecaster's own chance of this, stated with the estimate: 80%); the middle value lies on the limit itself.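

In this assay compound 4 gives > 36600 nM as a limit and not a number, so its steps from compound 1, compound 2 and compound 3 cannot be read. The compounds shown leave open whether any change on the shared core gives a measurable value, and how large a step fluoro in place of hydrogen makes.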